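Adding a second chloro to the core of compound 2

This account rests on a few compounds, and the source may have more. Where it says the series, first, only, none or still open, it means among the compounds named here.

Two compounds share the same fused two-ring core and differ in how the chlorobenzyl arm and the ring chlorines are arranged. Compound 1 `ClCc1ccccc1Cn1cnc2c(Cl)nc(Cl)nc21` carries two chloro groups on the core, and in a functional assay on A549 cells (Homo sapiens) for cytotoxicity, read by sulforhodamine B assay, with a stated time of 48 h (a lower number here means a stronger inhibitor of growth, a higher number a weaker inhibitor of growth), compound 1 gives 2230 nM. Compound 2 `ClCc1cccc(Cn2cnc3c(Cl)ncnc32)c1` carries only one, and in this assay compound 2 gives 19500 nM, the higher of the two numbers shown, a gap from compound 1 that goes beyond the scatter.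

Compound 3 `ClCc1cccc(Cn2cnc3c(Cl)nc(Cl)nc32)c1` is the next step: chloro in place of hydrogen on an aromatic carbon, between two ring nitrogen atoms and meta to a chloro group. For the measured compounds named here, no direct pairwise step between measured compounds exists for this change, so the only anchor is that compound 1, which already holds the second chloro, gives the lower value 2230 nM. A step downward from compound 2 to compound 3 is expected, estimated at a 4.3-fold lower number from compound 2 to compound 3 (0.64 log units; beyond the scatter). Compound 3 is therefore expected to give about 4500 nM, within a range of 1500 nM to 13000 nM.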

Compound 3, concentration for 50% growth inhibition: 3090 nM
Beside the measured number, compound 3's estimate is 1.5-fold (0.16 log units) above it, and the stated range covers the measured number.
By their numbers in this assay, from the lowest: compounds 1 and 3 (each within the scatter of the next); then compound 2.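

For the compounds shown here, the step gives the first direct reading of this change: in this assay, chloro in place of hydrogen on an aromatic carbon, between two ring nitrogen atoms, gives a 6.3-fold lower number from compound 2 to compound 3 (0.80 log units; beyond the scatter), so a single added chlorine at this position is enough to move the value beyond the scatter. It also separates the second chloro from the placement of the chlorobenzyl arm, which the earlier pair left tangled. With the second chloro present, compound 1 at 2230 nM and compound 3 at 3090 nM lie within the scatter of each other, although their arms are arranged differently. There is no supporting evidence that could explain why the added chloro has this effect on growth inhibition.

On these data alone, how an amine, a methoxy group or a fluoro group at this same position would compare with chloro remains open, since one substitution defines no trend across groups. Also open, as far as these compounds go, is whether the step would keep its size on the arrangement of the arm found in compound 1, and what replacing the chloromethyl group of the arm with a hydroxymethyl group would do.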